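Methoxy to hydroxy on the trifluoromethyl compound

The compounds below may be only part of what the source reports. "The series", "measured", "known", "first", "only" and "open" are said of these compounds alone.

In a functional assay on HepG2 cells (Homo sapiens) for antiproliferative activity, read by MTT assay, with a stated time of 24 h (a lower number here means a stronger inhibitor, a higher number a weaker inhibitor), compound 3 (`C=CCc1cc(-c2ccc(C(F)(F)F)cc2)ccc1OC`) gives 89000 nM and stands within the scatter of compound 2 (`C=CCc1cc(-c2ccc(NC(C)=O)cc2)ccc1OC`), which gives 60100 nM as its value. Within the data shown here, compound 1 (`C=CCc1cc(-c2ccc(F)cc2)ccc1O`), the only measured compound with a hydroxy, gives > 100000 nM as a limit of the assay and not a number. Compound 4 (`C=CCc1cc(-c2ccc(C(F)(F)F)cc2)ccc1O`) arises from compound 3 by hydrogen in place of methyl on an oxygen on an aromatic ring as methoxy to hydroxy. Among the measured compounds shown here, the one measured step (a 1.5-fold higher number from compound 2 to compound 3 (0.17 log units; within the scatter)) is a different change, so it bears only indirectly. No step beyond the scatter is therefore expected in this assay, and a limit remains possible. The expected step is small (a 1.0-fold higher number from compound 3 to compound 4 (0.00 log units; within the scatter)) in this estimate. For compound 4 the estimated value is 90000 nM within an expected range of 40000 nM to 200000 nM for now.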

Compound 4, half-maximal inhibitory concentration: 60300 nM
The estimate for compound 4 lay 1.5-fold (0.17 log units) above the measured number, and the stated range covers the measured number.
By their numbers in this assay, from the lowest: compounds 2, 4 and 3 (each within the scatter of the next). At a limit, above all of these: compound 1.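

Methoxy to hydroxy on the trifluoromethyl compounds gives a 1.5-fold lower number from compound 3 to compound 4 (0.17 log units; within the scatter) in this assay, so the two groups are not told apart on this oxygen. Trifluoromethyl in place of fluoro among the hydroxy compounds gives an at least 1.6-fold lower number from compound 1 to compound 4 (0.21 log units; that floor lies within the scatter), which is readable only as a floor. Compound 1 stands at a limit of the assay and not at a number: the limit of > 100000 nM in this assay, at which 1 of the 4 values shown sits.

From the compounds shown here alone, the true size of that step stays open. Also open, going by these compounds, is whether an amine in place of the hydroxy, or a longer chain in place of the methyl on that oxygen, would give a step beyond the scatter.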